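Methoxyphenyl variation: from compound 3 to compound 4

The source may report more compounds than this note shows. Statements on the series, on what has been measured and on what is new or still open speak of the compounds shown alone.

Measured in a functional assay on HeLa cells (Homo sapiens) for cytotoxicity, read by MTT assay, with a stated time of 72 h; on this read-out lower numbers stand for stronger inhibition and higher numbers for weaker inhibition:
- compound 1 `COc1cc(/C=C/C(=O)Nc2cc3c(Nc4ccc(F)c(Cl)c4)ncnc3cc2O[C@H]2CCOC2)cc(OC)c1OC` gives 24500 nM
- compound 2 `N#Cc1ccc(/C=C/C(=O)Nc2cc3c(Nc4ccc(F)c(Cl)c4)ncnc3cc2O[C@H]2CCOC2)cc1` gives "not determined" (no result reported)
- compound 3 `COc1ccc(/C=C/C(=O)Nc2cc3c(Nc4ccc(F)c(Cl)c4)ncnc3cc2O[C@H]2CCOC2)c(OC)c1OC` gives 4830 nM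

Of the two numbers available, the lower belongs to compound 3 at 4830 nM. Compound 2 adds no number to the comparison.

Next in the series is compound 4 `COc1cc(/C=C/C(=O)Nc2cc3c(Nc4ccc(F)c(Cl)c4)ncnc3cc2O[C@H]2CCOC2)cc(OC)c1`, with the shared core unchanged and the change confined to the aryl group: 3,5-dimethoxyphenyl in place of 2,3,4-trimethoxyphenyl on a double-bonded chain carbon bound to a double-bonded chain carbon. This puts 3,5-dimethoxyphenyl in place of 2,3,4-trimethoxyphenyl on a double-bonded chain carbon bound to a double-bonded chain carbon.

Among the measured compounds shown here, only one measured step bears on this change: a 5.1-fold lower number from compound 1 to compound 3 (0.71 log units; beyond the scatter). There, 2,3,4-trimethoxyphenyl stands in place of 3,4,5-trimethoxyphenyl at the same place, and the step is modest but beyond the scatter. For the measured compounds named here, no measured pair isolates the loss of a single methoxy group, so the evidence is thin. Compound 3 holds the lower number of this pair, and the group entering compound 4 no longer has the 2,3,4-trimethoxyphenyl name, so a move back towards compound 1 seems more likely than a further gain.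

The expected change in this assay is a 2.1-fold higher number from compound 3 to compound 4 (0.32 log units; beyond the scatter), a modest move towards a higher number.

For compound 4 the estimated value is 10000 nM, with an expected range from 3500 nM to 30000 nM.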

Compound 4, half-maximal inhibitory concentration: 34300 nM
For compound 4 the middle estimate is 3.4-fold (0.54 log units) below the measured one, outside the stated range (above it).
By their numbers in this assay, from the lowest: compound 3; then compounds 1 and 4 (each within the scatter of the next).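

In this assay, 3,5-dimethoxyphenyl in place of 2,3,4-trimethoxyphenyl on a double-bonded chain carbon bound to a double-bonded chain carbon gives a 7.1-fold higher number from compound 3 to compound 4 (0.85 log units; beyond the scatter), so the lower number of compound 3 does not carry over to this aryl group. Hydrogen in place of methoxy on an aromatic carbon gives a 1.4-fold higher number from compound 1 to compound 4 (0.15 log units; within the scatter), which leaves 3,4,5-trimethoxyphenyl and 3,5-dimethoxyphenyl level in this assay, and among the three aryl groups with numbers only 2,3,4-trimethoxyphenyl stands apart, with compound 3 at 4830 nM as the lowest value. Nothing at hand explains why this one arrangement of methoxy groups differs from the other two.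

The compounds shown do not separate whether the lower number of compound 3 depends on all of its methoxy groups or on only some of them, and the nitrile of compound 2 offers no number to set against them. Going by these compounds, it also remains open how a hydroxy group, a dimethylamino group or a carboxylic acid on the aromatic ring would compare with methoxy at this place.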